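The source may hold more compounds than are shown below. What is called first, only, known or untested is meant among the compounds shown, and "the series" means these compounds.

Compounds measured so far:
- compound 1, `CC(C)(C)c1ccc(C(=O)NCc2ccc(C(=O)O)cc2F)cc1`: 7.8 nM
- compound 2, `CC(C)(C)c1ccc(C(=O)NCc2ccc(-c3nnn[nH]3)cc2)cc1`: 120 nM
- compound 3, `CC(C)(C)c1ccc(C(=O)NCc2ccc(N)cc2Cl)cc1`: 46 nM

All three share a core and differ only in the groups on the outer aromatic ring. In an assay on HeLa cells with Bile acid receptor (Homo sapiens) as the target, read by a luciferase reporter, with a stated time of 24 h (a higher number here means that more compound is needed for the effect, a lower number that less compound is needed), compound 2 gives 120 nM, the highest of the three numbers, meaning it needs the most compound for the effect. Its nearest neighbour is compound 3, whose number lies beyond the scatter below it, and furthest away is compound 1, with a gap well beyond the scatter.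

The unmeasured compound 4, `CC(C)(C)c1ccc(C(=O)NCc2ccc(OC(F)(F)F)cc2)cc1`, is reached from compound 2 by one change: trifluoromethoxy in place of 1H-tetrazol-5-yl on an aromatic carbon. Among the compounds with values here, no measured pair shows this exact exchange, so no directly comparable step exists. Because compound 2 already stands at 120 nM and the acid-free compound 3 also reaches 46 nM, a loss of the tetrazole need not move the number far. The step from compound 2 to compound 4 in this assay is expected to be small, a 1.3-fold higher number from compound 2 to compound 4 (0.10 log units; within the scatter), within or near the scatter. Compound 4 is estimated at 150 nM, with a range of 30 nM to 700 nM.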

Compound 4, half-maximal effective concentration: 160 nM
Compound 4: middle estimate off by 1.1-fold (0.03 log units), on the low side; measured number inside the range.
By their numbers in this assay, from the lowest: compound 1; then compound 3; then compounds 2 and 4 (each within the scatter of the next).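

In this assay the exchange gives a 1.3-fold higher number from compound 2 to compound 4 (0.12 log units; within the scatter) and is the only single change that can be read among these compounds. On this aromatic carbon, para to a large group, 1H-tetrazol-5-yl gives way to trifluoromethoxy, a group of equal heavy-atom count with no ring and no hydrogen-bond donor, so in this pair neither that ring nor that donor is needed to hold the number where it stands. Nothing measured here explains why the two groups read alike.

Still open, on these data alone, is whether a much smaller group at this place, such as methyl or hydroxyl, would also leave the number within the scatter. Within the data shown here, no single-change step links compound 2 or compound 4 to compound 1 or compound 3, so the gaps to those two compounds cannot be traced to any one group.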